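The source may report more compounds than this note shows. Statements on the series, on what has been measured and on what is new or still open speak of the compounds shown alone.

Measured compounds in a functional assay on K562 cells (Homo sapiens) for cytotoxicity, read by sulforhodamine B assay, with a stated time of 48 h; on this read-out higher numbers stand for weaker inhibition of growth and lower numbers for stronger inhibition of growth:
compound 1 `ClCc1ccc(Cn2cnc3c(Cl)ncnc32)cc1`: 2910 nM
compound 2 `ClCc1ccc(Cn2cnc3nc(Cl)nc(Cl)c32)cc1`: 3310 nM
compound 3 `ClCc1ccc(Cn2cnc3c(Cl)nc(Cl)nc32)cc1`: 23400 nM

Compound 1 and compound 2 give numbers within the scatter of each other in this assay; compound 3 stands apart from both. Going by the values given here, the one counted change, (hydrogen in place of chloro on an aromatic carbon), gives an 8.0-fold lower number from compound 3 to compound 1 (0.91 log units; beyond the scatter). The cores of compound 2 and compound 3 carry the same atoms joined differently; the difference between the two cores is not broken down here.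

Compound 4 `ClCc1ccc(Cn2cnc3ncnc(Cl)c32)cc1` is not yet measured. Among the compounds with values here, it arises from compound 2 by hydrogen in place of chloro on an aromatic carbon, the same change as the one from compound 3 to compound 1, at a place described in identical words. Carried over as it stands, that step from compound 3 to compound 1, an 8.0-fold lower number from compound 3 to compound 1 (0.91 log units; beyond the scatter), would predict a much lower number, but compound 1 at 2910 nM shows that a single chloro analogue need not lie far below compound 2, so a more moderate step is expected: a 3.7-fold lower number from compound 2 to compound 4 (0.57 log units; beyond the scatter). Compound 4 is therefore estimated at 900 nM, likely between 300 nM and 3000 nM.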

Compound 4, concentration for 50% growth inhibition: 3010 nM
Compound 4: the middle estimate sits 3.3-fold (0.52 log units) below what was measured; measured number outside the range, above it.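

In this assay, hydrogen in place of chloro on an aromatic carbon gives a 1.1-fold lower number from compound 2 to compound 4 (0.04 log units; within the scatter). The size of this step does not carry over from one core to the other: the same change on two cores in this assay, an 8.0-fold lower number (0.91 log units; beyond the scatter) from compound 3 to compound 1 and a 1.1-fold lower number (0.04 log units; within the scatter) from compound 2 to compound 4, 7.3-fold (0.86 log units) apart, beyond the scatter of two such steps. These two pairs show that, for these compounds, a step measured on one core is a poor guide to the other, but they do not show what in the cores sets the gap, nor how the change behaves on any further core.

The compounds shown leave open what an amine or a methoxy group would give in place of the chloro on the core of compound 1 or compound 4. Also open, as far as these compounds go, is whether a hydroxymethyl group in place of the chloromethyl group would keep growth inhibition in this range.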